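The compounds below may be only part of what the source reports. "The series", "measured", "known", "first", "only" and "open" are said of these compounds alone.

In a functional assay on HCT-116 cells (Homo sapiens) for antiproliferative activity, read by MTT assay, with a stated time of 72 h (on this read-out higher numbers stand for weaker inhibition of growth and lower numbers for stronger inhibition of growth), compound 1 `COc1cc(OC)c(/C=C/S(=O)(=O)Cc2cnc(Cl)cn2)c(OC)c1` gives > 10000 nM, which is a limit of the assay and not a number. Compound 2 `CCOc1cnc(CS(=O)(=O)/C=C/c2c(OC)cc(OC)cc2OC)cn1` gives 1280 nM, and compound 3 `COc1cc(OC)c(/C=C/S(=O)(=O)Nc2ccc(Cl)nc2)c(OC)c1` gives 5640 nM, the higher of the two actual numbers in this small set. Compound 4 `COc1cc(OC)c(/C=C/S(=O)(=O)Nc2ccc(OC)nc2)c(OC)c1` has not yet been measured. It departs from compound 3 at a single place, methoxy in place of chloro on an aromatic carbon, next to the ring nitrogen. For the measured compounds named here, the closest precedent is an at least 7.8-fold lower number from compound 1 to compound 2 (0.89 log units; beyond the scatter), where ethoxy replaces chloro on a different ring. The other measured step, an at least 1.7-fold lower number from compound 1 to compound 3 (0.24 log units; that floor lies within the scatter), alters the group on the sulfonyl sulfur and does not test this kind of exchange. With a single precedent, whose size is bounded only from one side, a drop in the same direction is expected, though its size remains uncertain. The expected change is a 4.7-fold lower number from compound 3 to compound 4 (0.67 log units; beyond the scatter). For compound 4 the estimated value in this assay is 1200 nM, with an expected range from 200 nM to 6000 nM.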

Compound 4, concentration for 50% growth inhibition: 1000 nM
Beside the measured number, compound 4's estimate is 1.2-fold (0.08 log units) above it, within the range that was stated.
By their numbers in this assay, from the lowest: compounds 4 and 2 (each within the scatter of the next); then compound 3. At a limit, above all of these: compound 1.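

In this assay, methoxy in place of chloro on an aromatic carbon, next to the ring nitrogen and para to a large group, gives a 5.6-fold lower number from compound 3 to compound 4 (0.75 log units; beyond the scatter), a modest step with a measured number at both ends. The earlier exchange of chloro for ethoxy, on a different ring, could be bounded from one side only, because compound 1 sits at a limit: the limit of > 10000 nM in this assay, at which 1 of the 4 values shown sits. The direction seen there now has a size on a six-membered aromatic ring with 1 nitrogen, and neither of the two pairs of this kind goes against it.

The compounds shown leave open whether an amine, a plain hydrogen or a longer chain such as propoxy at this position would follow methoxy or chloro. They also leave open whether the step holds with another group on the sulfonyl sulfur.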